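The source may report more compounds than this note shows. Statements on the series, on what has been measured and on what is new or still open speak of the compounds shown alone.

Compound 1 `Fc1ccc(-c2nn3c(NC4CCCC4)cccc3c2-c2ccnc(NC3CCCC3)n2)cc1` and compound 2 `COc1ccc(-c2nn3c(NC4CCCC4)cccc3c2-c2ccnc(NC3CCCC3)n2)cc1` share one core; compound 3 `COc1ccc(-c2nn3c(NC4CCCC4)ccnc3c2-c2ccnc(NC3CCCC3)c2)cc1` and compound 4 `Fc1ccc(-c2nn3c(NC4CCCC4)ccnc3c2-c2ccnc(NC3CCCC3)c2)cc1` share another, and the difference between the two cores is not broken down here. In an ADME assay on Vero cells (Chlorocebus sabaeus) for cytotoxicity (on this read-out lower numbers stand for higher toxicity in this test and higher numbers for lower toxicity in this test), compound 1 gives only a limit, > 160000 nM. In this assay compound 2 likewise gives only a limit, > 100000 nM. Among the compounds with values here, compound 3 gives 10000 nM, the only number among the three. The step that the two limits leave unreadable from compound 2 to compound 1 is the change (fluoro in place of methoxy on an aromatic carbon); its size cannot be read because the limit of > 100000 nM in this assay, at which 1 of the 3 values shown sits, and the limit of > 160000 nM in this assay, at which 1 of the 3 values shown sits, mark both of its ends. Compound 4 carries the same change, (fluoro in place of methoxy on an aromatic carbon), on the core of compound 3. The measured step gives no size to lean on, so the expectation rests on compound 3 alone at 10000 nM. The step is expected to be small, a 1.2-fold higher number from compound 3 to compound 4 (0.08 log units; within the scatter). Compound 4 is thus estimated at 12000 nM, between 4000 nM and 40000 nM.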

Compound 4, half-maximal cytotoxic concentration: 16000 nM
Beside the measured number, compound 4's estimate is 1.3-fold (0.12 log units) below it; low and high end bracket the measured number.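

In this assay, the change from 4-methoxyphenyl to 4-fluorophenyl is a 1.6-fold higher number from compound 3 to compound 4 (0.20 log units; within the scatter), so on this core the swap does not move the read-out beyond the usual scatter. On the other core the same change has a limit at both ends, and that step cannot be read. The series therefore gives one readable size on one core, and it does not show whether the change behaves alike on both cores.

The compounds shown leave open how an amine, a carboxylic acid or a nitrile would read in place of fluoro on the same aromatic carbon. They also leave open the effect of the difference between the two cores, as no pair shown isolates it.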